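From cyclopentyl to 4-methoxyphenyl in a bombesin receptor series

The source may hold more compounds than are shown below. What is called first, only, known or untested is meant among the compounds shown, and "the series" means these compounds.

Three measured compounds share one core and differ only in the ring carried on a saturated chain carbon bound to an aromatic carbon. Compound 1 `O=C(O)c1ccccc1-c1ccc(CCc2ncc(CC3CCCCC3)[nH]2)cc1` gives 7.3 nM in an in vitro functional assay on cells for agonist activity at Bombesin receptor subtype-3 (Mus musculus), read by luminescence and calcium flux; a lower number here means that less compound is needed, a higher number that more compound is needed for the effect. Compound 2 `O=C(O)c1ccccc1-c1ccc(CCc2ncc(CC3CCC3)[nH]2)cc1` gives 7.1 nM in this assay. Compound 3 `O=C(O)c1ccccc1-c1ccc(CCc2ncc(CC3CCCC3)[nH]2)cc1` gives 7.9 nM in this assay, the highest of the three numbers, yet the step of a 1.1-fold higher number from compound 1 to compound 3 (0.03 log units; within the scatter) and the step of a 1.1-fold higher number from compound 2 to compound 3 (0.05 log units; within the scatter) both sit within the scatter, so the three numbers cannot be placed in an order.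

Compound 4 `COc1ccc(Cc2cnc(CCc3ccc(-c4ccccc4C(=O)O)cc3)[nH]2)cc1` is obtained from compound 3 by 4-methoxyphenyl in place of cyclopentyl on a saturated chain carbon bound to an aromatic carbon. The measured steps that come closest to this change are a 1.0-fold lower number from compound 1 to compound 2 (0.01 log units; within the scatter), a 1.1-fold higher number from compound 1 to compound 3 (0.03 log units; within the scatter) and a 1.1-fold higher number from compound 2 to compound 3 (0.05 log units; within the scatter), all exchanges of one saturated carbon ring for another at the same place, and none of them left the scatter. No measured step exchanges a saturated ring for an aromatic one, so the new change has no direct precedent among these compounds. On the evidence of the three flat steps, the step of a 1.3-fold higher number from compound 3 to compound 4 (0.10 log units; within the scatter) is expected to stay within the scatter, with a widened range to allow for the unprecedented ring type. Compound 4 is therefore estimated to give 10 nM in this assay, between 2 nM and 60 nM.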

Compound 4, half-maximal effective concentration: 513 nM
The estimate for compound 4 lay 51-fold (1.71 log units) below the measured number; measured number above the stated range.
By their numbers in this assay, from the lowest: compounds 2, 1 and 3 (each within the scatter of the next); then compound 4.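

The position that accepted every exchange among saturated carbon rings does not accept every ring: in this assay the change to 4-methoxyphenyl gives a 65-fold higher number from compound 3 to compound 4 (1.81 log units; beyond the scatter) when cyclopentyl leaves, a 72-fold higher number from compound 2 to compound 4 (1.86 log units; beyond the scatter) when cyclobutyl leaves and a 70-fold higher number from compound 1 to compound 4 (1.85 log units; beyond the scatter) when cyclohexyl leaves. All three steps are large and lie beyond the scatter, so the flat behaviour of compounds 1, 2 and 3 holds only among these saturated rings and does not carry over to this aromatic group, which brings one hydrogen-bond acceptor where the rings that leave bring none. Nothing available here accounts for the loss in terms of a measured property.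

The change swaps a saturated ring for an aromatic one and adds a methoxy group in a single step, and the compounds shown cannot separate these two parts. On these data alone, whether a plain phenyl ring would stay with compounds 1, 2 and 3 or go with compound 4, and how a cyclohexyl ring carrying a methoxy group would behave, remains open.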